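The source may hold more compounds than are shown below. What is called first, only, known or untested is meant among the compounds shown, and "the series" means these compounds.

Compound 1 `CCCCCc1ccc(NS(=O)(=O)c2ccc(N3CCNC3=O)cc2)cc1` is the starting point of this account. In a functional assay on MCF7 cells (Homo sapiens) for antiproliferative activity, read by sulforhodamine B assay, with a stated time of 48 h (on this read-out lower numbers stand for stronger inhibition and higher numbers for weaker inhibition), compound 1 gives only a limit, > 1000 nM, not a number. Compound 1 thus stands at the limit of > 1000 nM in this assay, at which 1 of the 3 values shown sits. Among the measured compounds shown here, its nearest measured neighbour is compound 3 `CCCCOc1ccc(NS(=O)(=O)c2ccc(N3CCNC3=O)cc2)cc1`, which in this assay gives 870 nM; the step of an at least 1.1-fold lower number from compound 1 to compound 3 (0.06 log units; that floor lies within the scatter) is the only measured step that touches compound 1, and it stays within the scatter. For the measured compounds named here, compound 2 `O=C1NCCN1c1ccc(S(=O)(=O)Nc2cccc(Br)c2)cc1` in this assay gives 100 nM; no single-point step links compound 2 to compound 1, so its value stands alone. The unmeasured compound 4 `O=C1NCCN1c1ccc(S(=O)(=O)Nc2ccc(I)cc2)cc1` differs from compound 1 by iodo in place of pentyl on an aromatic carbon. Going by the values given here, no measured step covers this exchange; the only guide is compound 2, whose halogen carries a far lower number than either pentyl or butoxy. Compound 4 is therefore expected to give 200 nM, with a range from 50 nM to 1000 nM, because compound 2 gives 100 nM. The expected step is an at least 5.0-fold lower number from compound 1 to compound 4 (0.69 log units; beyond the scatter).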

Compound 4, half-maximal inhibitory concentration: 600 nM
Compound 4: middle estimate off by 3.0-fold (0.48 log units), on the low side, and the stated range covers the measured number.
By their numbers in this assay, from the lowest: compound 2; then compounds 4 and 3 (each within the scatter of the next). At a limit, above all of these: compound 1.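

In this assay, iodo in place of pentyl on this aromatic carbon gives an at least 1.6-fold lower number from compound 1 to compound 4 (0.22 log units; that floor lies within the scatter), and iodo in place of butoxy gives a 1.5-fold lower number from compound 3 to compound 4 (0.16 log units; within the scatter), so at this place the iodo group does not set compound 4 apart from compound 3. Among the compounds shown here, compound 1 remains a limit, not a number: the limit of > 1000 nM in this assay, at which 1 of the 4 values shown sits. The low number of compound 2 does not carry over to compound 4: 4-iodophenyl in place of 3-bromophenyl on the sulfonamide nitrogen gives a 6.0-fold higher number from compound 2 to compound 4 (0.78 log units; beyond the scatter), the one new step clearly beyond the scatter, but this change alters both the halogen and its place, so neither can be credited alone.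

Going by these compounds, it remains open how a bromo group in place of the iodo of compound 4 would read, which would help to part halogen from place. On these data alone, it is equally open how an amine or a carboxylic acid in place of the pentyl of compound 1 would compare.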